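The source may hold more compounds than are shown below. What is called first, only, known or untested is meant among the compounds shown, and "the series" means these compounds.

Working notes on the series.

Of the compounds shown here, two of this set have been measured. Compound 1 `COc1ccc(C2SCC(=O)N2CCN2CCCCC2)cc1` and compound 2 `COc1ccccc1C1SCC(=O)N1CCN1CCCCC1` share the same core and differ only in the placement of the methoxy on the aromatic ring. In an ADME assay on Vero cells (Chlorocebus sabaeus) for cytotoxicity, read by neutral red uptake, tested at 25 ug/mL (a higher number here means a weaker effect of the compound at the concentration tested, a lower number a stronger effect), compound 1 gives 100%, and in this assay compound 2 gives 100%. Compound 1 therefore stands level with compound 2 at the digits recorded; the two readings lie within the scatter of each other, so nothing distinguishes them in this assay.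

Compound 3 `Cc1ccc(C2SCC(=O)N2CCN2CCCCC2)cc1` is the next member to be tested. Relative to compound 1 the change is methyl in place of methoxy on an aromatic carbon. Among the compounds with values here, no measured pair in this set tracks this kind of change, so the size of the step in this assay is unknown. Given that compound 1 gives 100% and compound 2 gives 100%, both at the top of the scale, a step of no size beyond the scatter is expected.

Compound 3 is thus expected to give 98% in this assay, within a range from 85% to 103%, which corresponds to an expected step of a number 2 percentage points lower from compound 1 to compound 3 (within the scatter).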

Compound 3, a percentage reported as activity, at one concentration (the size of the read-out at that concentration, not a potency): 100%
Beside the measured number, compound 3's estimate is 2 percentage points below it, within the range that was stated.
By their numbers in this assay, from the lowest: compounds 1, 2 and 3 (each within the scatter of the next).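

Methyl in place of methoxy on an aromatic carbon, para to a large group, is the first change in this set that replaces the substituent rather than moving it, and in this assay the step reads no change at the digits printed from compound 1 to compound 3 (within the scatter). At this position the read-out therefore does not separate methoxy, with its hydrogen-bond acceptor, from methyl, which has none, so neither the placement of the methoxy nor this exchange has yet given a reading apart from the others. Nothing to hand accounts for this flat result, and no explanation can be drawn from the data.

On these data alone, it remains open whether a different group at this position, such as an amine, a carboxylic acid or a longer alkyl chain, would give a reading beyond the scatter in this assay. As far as these compounds go, it is also open whether the three compounds would stay together at another concentration, since a single tested concentration gives the size of the read-out there and not a potency.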